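This account rests on a few compounds, and the source may have more. Where it says the series, first, only, none or still open, it means among the compounds named here.

Measured in a functional assay on A549 cells (Homo sapiens) for cytotoxicity, read by MTT assay, with a stated time of 48 h; a higher number here means a weaker inhibitor, a lower number a stronger inhibitor:
- Compound 1 `COc1cc(NC(=O)n2cc(-c3ccc(O)cc3)n(-c3cc(OC)c(OC)c(OC)c3)c2=O)cc(OC)c1OC`: 2500 nM
- Compound 2 `COc1ccc(-c2cn(C(=O)Nc3cc(OC)c(OC)c(OC)c3)c(=O)n2-c2cc(OC)c(OC)c(OC)c2)cc1N`: 11100 nM
- Compound 3 `COc1cc(-n2c(-c3ccccc3)cn(C(C)=O)c2=O)cc(OC)c1OC`: > 50000 nM

The value for compound 3 is a limit of the assay and not a number. Compound 3 thus stands at the limit of > 50000 nM in this assay, at which 1 of the 3 values shown sits, so the size of any step away from it cannot be read exactly.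

Compound 4 `COc1cc(-n2c(-c3ccc(Cl)cc3)cn(C(C)=O)c2=O)cc(OC)c1OC` carries chloro in place of hydrogen on an aromatic carbon, turning phenyl to 4-chlorophenyl: chloro in place of hydrogen on an aromatic carbon. Within the data shown here, no measured step makes this same exchange. The nearest evidence is a 4.4-fold higher number from compound 1 to compound 2 (0.65 log units; beyond the scatter), which also replaces one aryl group on an aromatic carbon with another, and it is modest. It bears on the new change only loosely, since the groups involved are different. A modest step at most is therefore expected in this assay. With compound 3 at a limit, the only direction that could be seen is toward a lower number, and compound 4 may well remain at the limit too.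

For compound 4, the expected value is 40000 nM, with an estimated range from 12000 nM to 100000 nM. The estimate amounts to an expected at least 1.2-fold lower number from compound 3 to compound 4 (0.09 log units; that floor lies within the scatter), and it is a rough one.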

Compound 4, half-maximal inhibitory concentration: > 50000 nM
Compound 4: a limit, no number; the forecaster's own chance of this, stated with the estimate: 55%; at least 1.2-fold (0.09 log units) between middle value and limit.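

In this assay compound 4 gives > 50000 nM, which is a limit and not a number. Compound 3 also stands at a limit, so no step between compound 3 and compound 4 can be read: the limit of > 50000 nM in this assay, at which 2 of the 4 values shown sit.

The compounds shown leave open whether chloro in place of hydrogen on the phenyl changes the value at all.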